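Cyclopentylamino purines: N-alkyl change at the imidazole nitrogen

The compounds below may be only part of what the source reports. "The series", "measured", "known", "first", "only" and "open" are said of these compounds alone.

Measured compounds in an assay on CHO cells for displacement of a labelled ligand from adenosine receptor A1 (Homo sapiens), read by scintillation counting, with a stated time of 3 h; on this read-out lower numbers stand for stronger inhibition and higher numbers for weaker inhibition:
compound 1 `Cn1c(-c2ccccc2)nc2c(NC3CCCC3)ncnc21` gives 2.8 nM
compound 2 `Cn1c(-c2cccc(Cl)c2)nc2c(NC3CCCC3)ncnc21` gives 6.5 nM
compound 3 `Cn1c(-c2ccc(O)cc2)nc2c(NC3CCCC3)ncnc21` gives 17 nM

Compound 1 has the lowest number of the three; the gap to compound 2 is a 2.3-fold higher number from compound 1 to compound 2 (0.37 log units; beyond the scatter) and to compound 3 a 6.1-fold higher number from compound 1 to compound 3 (0.78 log units; beyond the scatter), both beyond the scatter. Compound 4 `CCn1c(-c2ccccc2)nc2c(NC3CCCC3)ncnc21` is not yet measured. The change from compound 1 to compound 4 is methyl in place of hydrogen on a saturated chain carbon bound to an aromatic nitrogen. Going by the values given here, all three measured steps alter the phenyl ring, none the methyl on the aromatic nitrogen, so no measured step bears directly on this change. In the absence of such a step, the expected step for compound 4 is a 1.3-fold higher number from compound 1 to compound 4 (0.10 log units; within the scatter), that is none beyond the scatter, and the estimate for compound 4 in this assay is 3.5 nM, within 1.5 nM to 9 nM.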

Compound 4, inhibition constant: 3.9 nM
For compound 4 the middle estimate is 1.1-fold (0.05 log units) below the measured one, within the range that was stated.
By their numbers in this assay, from the lowest: compounds 1, 4 and 2 (each within the scatter of the next, the first and the last beyond it); then compound 3.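

Unlike the steps on the phenyl ring, methyl to ethyl at the aromatic nitrogen gives a 1.4-fold higher number from compound 1 to compound 4 (0.14 log units; within the scatter) in this assay, so one added carbon at this position leaves the number within the scatter. No supporting data bear on this result. Still open, as far as these compounds go, is whether a longer chain, a cyclopropylmethyl group or a chain ending in an amine or a carboxylic acid would stay within the scatter too. Also open, from the compounds shown here alone, is whether ethyl behaves the same way alongside the 3-chlorophenyl or 4-hydroxyphenyl groups.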